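Trifluoromethyl in Place of Hydroxy on the Amide Aryl

A few compounds are considered here, and "the series" means these few. Any claim that something is new, unique, unknown or untested is made for them only; others in the source may bear on it.

Among the measured compounds shown here, compound 1 `O=C(Nc1ccc(O)cc1)C1NCCc2ccccc21` is the only member of the series with a number in a functional assay on NUGC-3 cells (Homo sapiens) for inhibition, read by sulforhodamine B assay, with a stated time of 48 h; a lower number here means a stronger inhibitor of growth, a higher number a weaker inhibitor of growth: compound 1 gives 4370 nM. For the measured compounds named here, compound 2 `O=C(Nc1ccc(C(F)(F)F)cc1)c1nccc2ccccc12` has a different core and a different substituent on the amide aryl, so it differs from compound 1 in two places and no single step between the measured pair can be drawn. In this assay compound 2 gives only a limit, > 10000 nM. Of the two values shown, then, one is a number and the other is the limit of > 10000 nM in this assay, at which 1 of the 2 values shown sits.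

Compound 3 `O=C(Nc1ccc(C(F)(F)F)cc1)C1NCCc2ccccc21` has not been measured. It differs from compound 1 by trifluoromethyl in place of hydroxy on an aromatic carbon. Going by the values given here, the only measured compound carrying the trifluoromethyl, compound 2, sits at the limit > 10000 nM. On that basis a weakening is expected rather than no change. The step of a 2.1-fold higher number from compound 1 to compound 3 (0.31 log units; beyond the scatter) is expected to lie beyond the usual scatter, toward weaker growth inhibition. Compound 3 is expected to give about 9000 nM in this assay, within a range of 3500 nM to 20000 nM, with a fair chance that only a limit is reported.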

Compound 3, concentration for 50% growth inhibition: 4220 nM
The estimate for compound 3 lay 2.1-fold (0.33 log units) above the measured number; low and high end bracket the measured number.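

In this assay, the step of a 1.0-fold lower number from compound 1 to compound 3 (0.02 log units; within the scatter) shows that on the shared core, trifluoromethyl can stand in place of hydroxy on this aromatic carbon, para to a large group, without a readable change in growth inhibition. The hydroxy, with its hydrogen-bond donor and acceptor, is therefore not required at this position for a number of this size on this core, and the four heavy atoms of trifluoromethyl are accommodated there without a readable change. Compound 2 carries the same trifluoromethyl on a different core and stands only at a limit, so that limit cannot be tied to the trifluoromethyl alone: the limit of > 10000 nM in this assay, at which 1 of the 3 values shown sits.

From the compounds shown here alone, only hydroxy and trifluoromethyl are compared at this position, and whether an amine, a carboxylic acid or a methoxy group there would leave the number unchanged remains open. Going by these compounds, with a limit on one side, the gap between compound 3 and compound 2 has no size, and how much the core contributes to growth inhibition is also open.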